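This account rests on a few compounds, and the source may have more. Where it says the series, first, only, none or still open, it means among the compounds named here.

Working notes on the series. Activity is followed in an assay on HEK293 cells for activation of Kir3.1/Kir3.2 (Homo sapiens), read by thallium flux; on this read-out lower numbers stand for an effect already at smaller amounts and higher numbers for an effect only at larger amounts of compound. Compound 1 `Cc1cc(NC(=O)Cn2nnc(-c3ccccc3)n2)n(C2CCS(=O)(=O)C2)n1` gives 1030 nM, compound 2 `CC1CC1c1cc(NC(=O)Cn2nnc(-c3ccccc3)n2)n(C2CCCCC2)n1` gives 843 nM, and compound 3 `Cc1cc(NC(=O)Cn2nnc(-c3cc(Cl)cc(Cl)c3)n2)n(C2CCCCC2)n1` gives 980 nM. On these numbers compound 3 stands second highest of the three; its nearest neighbour is compound 1, a gap within the scatter, and its furthest is compound 2, a gap also within the scatter, so the three measured compounds cannot be told apart on this read-out.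

For the measured compounds named here, no two measured compounds differ in a single place, so no measured step is available to lean on. The next compound, compound 4 `Cc1cc(NC(=O)Cn2nnc(C3CC3)n2)n(C2CCCCC2)n1`, differs from compound 3 in one place: cyclopropyl in place of 3,5-dichlorophenyl on an aromatic carbon. The group that leaves is the only aromatic ring on that carbon among the measured compounds, and nothing measured shows what a small non-aromatic ring there does in this assay.

Going by the values given here, with no measured step to guide it, the expectation for this assay is a move toward a higher number, beyond the scatter, and the expected step is a 3.6-fold higher number from compound 3 to compound 4 (0.55 log units; beyond the scatter). Compound 4 is estimated at 3500 nM, with a range from 1200 nM to 12000 nM, and a real chance that only a limit is reported.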

Compound 4, half-maximal effective concentration: > 3000 nM
Compound 4 was reported as a limit; the forecaster's own chance of this, stated with the estimate: 30%; the middle value lies beyond the limit too.
By their numbers in this assay, from the lowest: compounds 2, 3 and 1 (each within the scatter of the next). At a limit, above all of these: compound 4.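

In this assay, cyclopropyl in place of 3,5-dichlorophenyl on an aromatic carbon of a five-membered aromatic ring with 4 nitrogen gives an at least 3.0-fold higher number from compound 3 to compound 4 (0.48 log units; beyond the scatter) in the first single-place comparison available in the series. This position is therefore not indifferent to the group it carries, although the three earlier compounds could not be told apart on this read-out. Compound 4 is reported only as a limit (> 3000 nM), so the step gives a direction and a minimum size, but not a full size: the limit of > 3000 nM in this assay, at which 1 of the 4 values shown sits.

Compounds 1 and 2 carry phenyl at this place but also differ from compound 3 elsewhere, so steps to them cannot be read, and the shift cannot be divided between loss of the aromatic ring and loss of the two chlorine atoms. Also open, on these data alone, is how this position responds to a group of another kind, such as a carboxylic acid, an amine or a longer carbon chain, and whether any group there gives a lower number than the 3,5-dichlorophenyl of compound 3.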